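Removing the Amine Methyl in a Cyclic Sulfonamide Series

The source may report more compounds than this note shows. Statements on the series, on what has been measured and on what is new or still open speak of the compounds shown alone.

In an assay on isolated protein (Cricetulus griseus) for binding affinity to Alpha-1B adrenergic receptor (Mesocricetus auratus), read by radioligand binding (a higher number here means a weaker inhibitor, a lower number a stronger inhibitor), compound 1 `CS(=O)(=O)Nc1cccc2c1CCCCC2c1c[nH]cn1` gives 10000 nM. Compound 2 `CCS(=O)(=O)Nc1cccc2c1CCCC2c1c[nH]cn1` gives 1320 nM in this assay. Compound 3 `CCS(=O)(=O)Nc1cccc2c1CCCC2CNC` carries a (methylamino)methyl group in place of the 1H-imidazol-4-yl group of compound 2, and in this assay compound 3 gives < 10000 nM, which is a limit of the assay and not a number. Compound 3 therefore stands at the limit, and the step that the limit leaves unreadable from compound 2 to compound 3 cannot be read, because the limit of < 10000 nM in this assay, at which 1 of the 3 values shown sits, describes its value.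

Compound 4 `CCS(=O)(=O)Nc1cccc2c1CCCC2CN` differs from compound 3 by hydrogen in place of methyl on an amine nitrogen. Among the compounds with values here, no measured step in this assay touches the amine nitrogen, and the only step that involves compound 3 is unreadable, so there is nothing to suggest a direction or a size for this assay beyond the scatter. The expected step that the limit leaves unreadable from compound 3 to compound 4 is accordingly set near nothing, and compound 4 is estimated to give 5000 nM in this assay, in a range from 1000 nM to 10000 nM.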

Compound 4, inhibition constant: < 10000 nM
Compound 4: a limit, no number; the forecaster's own chance of this, stated with the estimate: 60%; the middle value is on the limit's open side.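

Compound 4 gives < 10000 nM in this assay as a limit and not a number. Within the data shown here, no step from compound 2 or compound 3 to compound 4 can be read, because the value of compound 4 is such a limit: the limit of < 10000 nM in this assay, at which 2 of the 4 values shown sit. The compounds shown leave open whether hydrogen in place of methyl on the amine nitrogen changes binding affinity at all.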